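Rotarod series: amide nitrogen alkyl variation on two cores

The source may report more compounds than this note shows. Statements on the series, on what has been measured and on what is new or still open speak of the compounds shown alone.

Compound 1 `CCN(C)C(=O)/C=C1\CCc2c(F)cc(F)cc21` and compound 2 `CN(C)C(=O)/C=C1\CCc2c(F)cc(F)cc21` share one core; compound 3 `CCNC(=O)/C=C1\CCc2ccc(F)cc21` and compound 4 `CC(C)NC(=O)/C=C1\CCc2ccc(F)cc21` share another, and the difference between the two cores is not broken down here. In a functional assay on the whole organism with Mus musculus as the target, in the rotarod test (a lower number here means that less compound is needed, a higher number that more compound is needed for the effect), compound 1 gives 73 mg/kg, compound 2 gives 100 mg/kg and compound 3 gives 136 mg/kg. Compound 2 and compound 1 differ by methyl in place of hydrogen on a saturated chain carbon bound to an amide-type nitrogen, a change that made a 1.4-fold lower number from compound 2 to compound 1 (0.14 log units; within the scatter). Compound 3 and compound 4 differ by methyl in place of hydrogen on a saturated chain carbon bound to an amide-type nitrogen and a saturated chain carbon; this is the same kind of change, though the place now is a saturated chain carbon bound to an amide-type nitrogen and a saturated chain carbon, not one bound to an amide-type nitrogen alone. Beside the earlier 1.4-fold lower number from compound 2 to compound 1 (0.14 log units; within the scatter), the expected step is a 1.2-fold lower number from compound 3 to compound 4 (0.09 log units; within the scatter), resting on that single precedent on a different core. Compound 4 is therefore estimated at 110 mg/kg.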

Compound 4, dose for half-maximal effect: > 100 mg/kg
Compound 4 ended at the assay's limit; the forecaster's own chance of this, stated with the estimate: 10%; the middle value is on the limit's open side.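

In this assay compound 4 gives > 100 mg/kg, a limit of the assay, so no step can be read between compound 3 and compound 4. The compounds shown leave open whether ethyl to isopropyl changes the number on this core.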